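Chloro on the core: compound 1 to compound 4

The compounds below may be only part of what the source reports. "The series", "measured", "known", "first", "only" and "open" are said of these compounds alone.

Measured so far:
compound 1 `COc1ccc2[nH]cc(-c3cnc(N(C)[C@@H]4C[C@H]5O[C@@](C)([C@@H]4OC)n4c6ccccc6c6c7c(c8c9ccccc9n5c8c64)C(=O)NC7)s3)c2c1` — 360 nM
compound 2 `CO[C@@H]1[C@H](N(C)c2ncc(-c3c[nH]c4ccccc34)s2)C[C@H]2O[C@]1(C)n1c3ccccc3c3c4c(c5c6cc(Cl)ccc6n2c5c31)C(=O)NC4` — 560 nM
compound 3 `CO[C@@H]1[C@H](N(C)c2ncc(-c3c[nH]c4ccc(F)cc34)s2)C[C@H]2O[C@]1(C)n1c3ccccc3c3c4c(c5c6cc(Cl)ccc6n2c5c31)C(=O)NC4` — 320 nM

In a functional assay on MV4-11 cells (Homo sapiens) for antiproliferative activity, read by CellTiter-Glo, with a stated time of 72 h (a lower number here means a stronger inhibitor, a higher number a weaker inhibitor), compound 1 gives 360 nM; it stands second highest of the three numbers, nearest compound 3 and furthest from compound 2, and both gaps lie within the scatter. Within the data shown here, the one measured single-point step, a 1.8-fold lower number from compound 2 to compound 3 (0.24 log units; within the scatter), concerns a fluoro on the aromatic substituent, not the core, and is itself within the scatter.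

Compound 4 `COc1ccc2[nH]cc(-c3cnc(N(C)[C@@H]4C[C@H]5O[C@@](C)([C@@H]4OC)n4c6ccccc6c6c7c(c8c9cc(Cl)ccc9n5c8c64)C(=O)NC7)s3)c2c1` differs from compound 1 by chloro in place of hydrogen on an aromatic carbon. Among the measured compounds shown here, no measured pair isolates this change: compounds 2 and 3 carry the chloro on the core but differ from compound 1 in the substituent as well, and their numbers sit within the scatter of compound 1 in this assay. Nothing in the series therefore points to a step beyond the scatter, in either direction.

Compound 4 is expected to give about 330 nM in this assay, from 150 nM to 750 nM, so that the expected step of a 1.1-fold lower number from compound 1 to compound 4 (0.04 log units; within the scatter) stays inside the usual scatter.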

Compound 4, half-maximal inhibitory concentration: 440 nM
Compound 4: the middle estimate sits 1.3-fold (0.12 log units) below what was measured; low and high end bracket the measured number.
By their numbers in this assay, from the lowest: compounds 3, 1, 4 and 2 (each within the scatter of the next).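

In this assay the shared core now has a matched pair for chloro in place of hydrogen on an aromatic carbon (a 1.2-fold higher number from compound 1 to compound 4 (0.09 log units; within the scatter)), so this position, on a six-membered aromatic ring of carbon only, tolerates the chloro with no step beyond the scatter. With the chloro in place, the aromatic substituent also shows no step beyond the scatter for methoxy in place of hydrogen (a 1.3-fold lower number from compound 2 to compound 4 (0.10 log units; within the scatter)) or for methoxy in place of fluoro (a 1.4-fold higher number from compound 3 to compound 4 (0.14 log units; within the scatter)), so neither site separates these compounds in this assay. No measurement is available that would explain these small steps or connect them to any property of the groups.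

Still open, on these data alone, is whether an amine, a carboxylic acid or a longer chain on the same aromatic carbon would give a step beyond the scatter in this assay. A single halogen on one carbon of the core says little about the rest of that ring, and other groups there could behave quite differently from chloro.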